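A few compounds are considered here, and "the series" means these few. Any claim that something is new, unique, unknown or untested is made for them only; others in the source may bear on it.

Three compounds have been measured in an assay on CHO cells for displacement of a labelled ligand from adenosine receptor A1 (Homo sapiens), read by scintillation counting, with a stated time of 3 h; a higher number here means a weaker inhibitor, a lower number a stronger inhibitor:

compound 1 `CCn1c(-c2ccccc2)nc2c(NC3CCCCC3)ncnc21` — 10 nM
compound 2 `Cn1c(-c2ccccc2)nc2c(NC3CCCCC3)ncnc21` — 5.7 nM
compound 3 `CCn1c(-c2ccccc2)nc2c(NC3CCC3)ncnc21` — 6 nM

Compound 3 stands in the middle of these three numbers, but none of them is separated from another beyond the usual scatter: the step of a 1.7-fold lower number from compound 1 to compound 3 (0.22 log units; within the scatter) is within it, and the values of compound 3 and compound 2 likewise lie within the scatter of each other. Compound 4 `CCCn1c(-c2ccccc2)nc2c(NC3CCC3)ncnc21` differs from compound 3 in one place: methyl in place of hydrogen on a saturated chain carbon, two bonds along the chain from an aromatic nitrogen.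

Within the data shown here, the one measured step that bears on the chain attached to the aromatic nitrogen is a 1.8-fold lower number from compound 1 to compound 2 (0.24 log units; within the scatter), a change in this chain by one carbon that stayed within the scatter. The step from compound 1 to compound 3 concerns the other site and says nothing about the chain. On this basis no change beyond the scatter is expected from lengthening the chain by one further carbon. For compound 4 the estimated value in this assay is 6 nM, with an expected range from 2.5 nM to 15 nM. The step of no change at the digits printed from compound 3 to compound 4 (within the scatter) that this estimate means is expected to stay within the scatter.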

Compound 4, inhibition constant: 15 nM
Estimate against measurement, compound 4: 2.5-fold (0.40 log units) below; measured number inside the range.
By their numbers in this assay, from the lowest: compounds 2, 3, 1 and 4 (each within the scatter of the next, the first and the last beyond it).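

Among these compounds, on the chain at the aromatic nitrogen, going from ethyl to propyl gives the first step at this position that lies beyond the scatter in this assay, a 2.5-fold higher number from compound 3 to compound 4 (0.40 log units; beyond the scatter), whereas the earlier change at this position, from ethyl to methyl, stayed within it. This position is therefore not wholly indifferent to chain length, although the effect remains modest. Even so, the two steps cannot be told apart, so the compounds shown give no sign that the change reads differently on the two cores: the same change on two cores in this assay, a 1.8-fold lower number (0.24 log units; within the scatter) from compound 1 to compound 2 and a 2.5-fold lower number (0.40 log units; beyond the scatter) from compound 4 to compound 3, 1.4-fold (0.15 log units) apart, within the scatter of two such steps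

The compounds shown leave open how a butyl chain, a branched isopropyl group or a chain ending in an amine or a hydroxyl group would read at this position. They also leave open whether a propyl chain gives a similar step when cyclohexyl, not cyclobutyl, sits on the nitrogen on the aromatic ring.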